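Ring-nitrogen acylation in the nitrophenyl dihydropyrimidinone series

The source may hold more compounds than are shown below. What is called first, only, known or untested is meant among the compounds shown, and "the series" means these compounds.

Among the compounds with values here, compound 2 `CC1=C(C(=O)OC(C)C)C(c2cccc([N+](=O)[O-])c2)NC(=O)N1` gives 46600 nM in an assay on HEK293 cells for antagonist activity at Voltage-dependent L-type calcium channel subunit alpha-1D (Rattus norvegicus), read by FLIPR (on this read-out higher numbers stand for weaker inhibition and lower numbers for stronger inhibition), the highest of the three numbers so far. Within the data shown here, compound 1 `COC(=O)C1=C(C)NC(=O)NC1c1cccc([N+](=O)[O-])c1` gives 18900 nM in this assay, and the step of a 2.5-fold higher number from compound 1 to compound 2 (0.39 log units; beyond the scatter) is the only one-change step in hand. Compound 3 `COC(=O)C1=C(C(C)C)NC(=O)N(C(=O)OC(C)C)C1c1cccc([N+](=O)[O-])c1` gives 10100 nM in this assay; it differs from compound 1 in two places, so its values and those of compound 1 only show that the acylated ring and the branched substituent together sit at a lower number. Compound 4 `CC1=C(C(=O)OC(C)C)C(c2cccc([N+](=O)[O-])c2)N(C(=O)OC(C)C)C(=O)N1` carries isopropoxycarbonyl in place of hydrogen on an amide-type nitrogen in a ring. Among the measured compounds shown here, no measured step isolates this change, so no step beyond the scatter is expected, with a slight lean to a lower number, a 1.5-fold lower number from compound 2 to compound 4 (0.16 log units; within the scatter). Compound 4 is estimated at 32000 nM in this assay, range 12000 nM to 80000 nM.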

Compound 4, half-maximal inhibitory concentration: 660 nM
Estimate against measurement, compound 4: 48-fold (1.69 log units) above, outside the stated range (below it).
By their numbers in this assay, from the lowest: compound 4; then compounds 3 and 1 (each within the scatter of the next); then compound 2.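

In this assay, within the data shown here, isopropoxycarbonyl in place of hydrogen on the amide-type nitrogen in the ring gives a 71-fold lower number from compound 2 to compound 4 (1.85 log units; beyond the scatter), the first isolated reading of this position. Among these compounds, this step is large and runs in the opposite direction to the only other one-change step, the modest 2.5-fold higher number from compound 1 to compound 2 (0.39 log units; beyond the scatter), for isopropyl in place of methyl. Nothing measured here accounts for the size of the step.

Going by these compounds, whether the lower number depends on the carbonyl or on the isopropyl part stays open. An acetyl group or a longer alkoxycarbonyl chain on this nitrogen would help separate the two.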